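Butyl in Place of Cyclopropyl on the Ring Nitrogen

The source may hold more compounds than are shown below. What is called first, only, known or untested is meant among the compounds shown, and "the series" means these compounds.

Measured compounds:
compound 1, `Cc1cccc(CSc2nc3cc(NC(=O)C4CC4)ccc3n2C(C)C)c1`: 6500 nM
compound 2, `COc1ccc([N+](=O)[O-])cc1CSc1nc2cc(NC(=O)NC(C)(C)C)ccc2n1C1CC1`: 79 nM

In an assay on isolated protein for inhibition of Gonadotropin-releasing hormone receptor (Homo sapiens) (on this read-out lower numbers stand for stronger inhibition and higher numbers for weaker inhibition), compound 1 gives 6500 nM. In the same assay compound 2 gives 79 nM, the lowest of the two numbers; compound 1 stands far higher, well beyond the scatter, but the two compounds differ in several places at once, so no single change can be read from that gap.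

Compound 3 `CCCCn1c(SCc2cc([N+](=O)[O-])ccc2OC)nc2cc(NC(=O)NC(C)(C)C)ccc21` is the next step. Its change from compound 2 is butyl in place of cyclopropyl on an aromatic nitrogen. Among the compounds with values here, no measured pair differs in this one place alone, so the size of this step is not known from the data. Both groups are small carbon pieces with no donors or acceptors, and a modest step is expected in this assay, within the scatter or slightly toward weaker inhibition. The step from compound 2 to compound 3 is estimated at a 1.4-fold higher number from compound 2 to compound 3 (0.14 log units; within the scatter). For compound 3 the expected value is 110 nM, with a range from 30 nM to 400 nM.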

Compound 3, half-maximal inhibitory concentration: 23 nM
For compound 3 the middle estimate is 4.8-fold (0.68 log units) above the measured one; measured number below the stated range.
By their numbers in this assay, from the lowest: compound 3; then compound 2; then compound 1.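

This is the first step shown that changes one place alone, and it shows that the group on the aromatic nitrogen affects the result in this assay. Butyl in place of cyclopropyl gives a 3.4-fold lower number from compound 2 to compound 3 (0.54 log units; beyond the scatter), so at this place an open chain with no ring goes with stronger inhibition than the small carbon ring in compound 2. No measurement here explains the direction or size of this step.

The compounds shown leave open whether the gain follows from the longer chain or from the loss of the ring; a propyl, a pentyl or a cyclobutyl on the same nitrogen would help to separate the two. Going by these compounds, it also remains open whether the same change would give a similar step with the other groups of compound 1.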